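Phenyl to methyl on the chain, across two cores

The source may hold more compounds than are shown below. What is called first, only, known or untested is meant among the compounds shown, and "the series" means these compounds.

Of the compounds shown here, three have been measured in an assay on isolated protein for inhibition of acid ceramidase (Homo sapiens), read by LC-MS, with a stated time of 1 h; on this read-out higher numbers stand for weaker inhibition and lower numbers for stronger inhibition. Compound 1 `O=C(NCCCCc1ccccc1)n1c(-c2ccccc2)coc1=O` gives 70 nM. Compound 2 `CCCCCNC(=O)n1c(-c2ccccc2)coc1=O` gives 25 nM. Compound 3 `CN1CCC(c2cc(F)ccc2-c2cn(C(=O)NCCCCc3ccccc3)c(=O)o2)CC1` gives 337 nM, the highest of the three numbers: against compound 1 and compound 2 its steps are both beyond the scatter.

Between compound 1 and compound 2 the change is methyl in place of phenyl on a saturated chain carbon, four bonds along the chain from an amide-type nitrogen. The step it made is a 2.8-fold lower number from compound 1 to compound 2 (0.45 log units; beyond the scatter), a modest gain on the side of stronger inhibition.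

Compound 3 carries a different core from compound 1 and compound 2, and the difference between the two cores is not broken down here. Compound 4 `CCCCCNC(=O)n1cc(-c2ccc(F)cc2C2CCN(C)CC2)oc1=O`, not yet measured, is related to compound 3 by methyl in place of phenyl on a saturated chain carbon, four bonds along the chain from an amide-type nitrogen. For the measured compounds named here, this is the same change as the one from compound 1 to compound 2, at the same place, only made on the core of compound 3.

Expectation for compound 4 in this assay: a step of similar direction and size to the earlier one, because a 2.8-fold lower number from compound 1 to compound 2 (0.45 log units; beyond the scatter) is the only measured instance of this change; it is carried over from the core of compound 1 to the core of compound 3, which is itself a different starting point at 337 nM, so the range is kept wide. The expected step is a 2.8-fold lower number from compound 3 to compound 4 (0.45 log units; beyond the scatter). Compound 4 is estimated at 120 nM, between 55 nM and 260 nM.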

Compound 4, half-maximal inhibitory concentration in the acid ceramidase assay: 129 nM
The estimate for compound 4 lay 1.1-fold (0.03 log units) below the measured number; the range from low to high includes it.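

In the acid ceramidase assay the replacement of phenyl by methyl on the chain gives a 2.6-fold lower number from compound 3 to compound 4 (0.42 log units; beyond the scatter), and the change carries from one core to the other with its direction and size preserved: the same change on two cores in the acid ceramidase assay, a 2.8-fold lower number (0.45 log units; beyond the scatter) from compound 1 to compound 2 and a 2.6-fold lower number (0.42 log units; beyond the scatter) from compound 3 to compound 4, 1.1-fold (0.03 log units) apart, within the scatter of two such steps

This agreement rests on a single pair on each core, so it supports transfer between the core of compound 1 and the core of compound 3 only, sets no rule for any other core, and does not explain why the step takes this size. In a physicochemical assay for solubility, read by HPLC, in phosphate buffer, measured as kinetic solubility, with a stated time of 1 h, at pH 7.4, tested at 250 uM (on this read-out lower numbers stand for lower solubility and higher numbers for higher solubility), compound 3 gives 60000 nM. In the physicochemical assay compound 4 gives > 250000 nM, which is a limit of the assay and not a number. In the physicochemical assay the same change gives an at least 4.1-fold higher number from compound 3 to compound 4 (0.61 log units; beyond the scatter), a step set by that limit on compound 4, so only its direction and a minimum size can be read, and no pair on a second core stands beside it: the limit of > 250000 nM in the physicochemical assay, at which 1 of the 2 values shown sits.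

The compounds shown leave open whether the step would hold with a longer alkyl chain, or with a chain ending in an amine or a carboxylic acid. They also leave open which part of the difference between the two cores matters in the acid ceramidase assay, and whether a third core would give a step of the same size.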